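Swapping fluoro for trifluoromethyl on the anilide ring

The compounds below may be only part of what the source reports. "The series", "measured", "known", "first", "only" and "open" are said of these compounds alone.

Measured compounds:
Compound 1 `CC(=O)Nc1ccc(Cc2noc(CCC(=O)O)n2)cc1`: in a functional assay on the whole organism (strain C57BL/6) for inhibition, with Mus musculus as the target, read by paw edema, with stated times of 1 h and 4 h, at a dose of 100 mg/kg by the oral route (a higher number here means more inhibition at the dose given (going by the name of the read-out), a lower number less inhibition), compound 1 gives 75.3%.
Compound 2 `COc1cccc(NC(=O)CCc2nc(Cc3ccc(NC(C)=O)cc3)no2)c1`: in this assay compound 2 gives 35.6%.
Compound 3 `CC(=O)Nc1ccc(Cc2noc(CCC(=O)Nc3ccc(F)cc3)n2)cc1`: in this assay compound 3 gives 64.4%.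

Compound 3 stands second of the three numbers: below compound 1, as a number 10.9 percentage points lower from compound 1 to compound 3 (beyond the scatter) shows, and above compound 2, as a number 28.8 percentage points higher from compound 2 to compound 3 (beyond the scatter) shows. Compound 4 `CC(=O)Nc1ccc(Cc2noc(CCC(=O)Nc3ccc(C(F)(F)F)cc3)n2)cc1` differs from compound 3 in one place: trifluoromethyl in place of fluoro on an aromatic carbon.

Among the measured compounds shown here, no measured step exchanges one substituent on that ring for another, so none bears on this change directly. The step of a number 28.8 percentage points higher from compound 2 to compound 3 (beyond the scatter) shows that the group on the amide nitrogen can move the number by a modest amount, and a number 10.9 percentage points lower from compound 1 to compound 3 (beyond the scatter) shows the anilide itself costs a little against the acid. The expected step of a number 8.4 percentage points lower from compound 3 to compound 4 (within the scatter) is therefore small, with a wide range. Compound 4 is estimated at 56% in this assay, between 35% and 75%.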

Compound 4, a percentage reported as inhibition, in the whole organism at one dose (the size of the read-out at that dose, not a potency): 37%
For compound 4 the middle estimate is 19 percentage points above the measured one; the measured number falls inside the stated range.
By their numbers in this assay, from the lowest: compounds 2 and 4 (each within the scatter of the next); then compound 3; then compound 1.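

In this assay, exchanging fluoro for trifluoromethyl gives a number 27.4 percentage points lower from compound 3 to compound 4 (beyond the scatter), so the substituent on the anilide ring matters on its own, with the rest of the molecule unchanged. Among the compounds shown here, the other steps replace the acid's hydroxy or a whole aryl group, and this one is the only step that keeps the ring and alters just its substituent. The comparison of the two anilides with different rings gives a number 1.4 percentage points higher from compound 2 to compound 4 (within the scatter), so a 4-(trifluoromethyl)phenyl and a 3-methoxyphenyl group on the amide nitrogen cannot be told apart here, while 4-fluorophenyl stands clear of both.

Nothing shown gives a reason for the drop on going to trifluoromethyl. Going by these compounds, what a chloro group, a methyl group or an amine on the same aromatic carbon would give stays open, as does the effect of a hydrogen there.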